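A few compounds are considered here, and "the series" means these few. Any claim that something is new, unique, unknown or untested is made for them only; others in the source may bear on it.

Compound 2 `CCN(CC)CCNC(=O)CC(=O)N1CCSC1COc1ccccc1OC` is the higher of the two numbers measured in a functional assay on the whole organism for inhibition, with Cavia porcellus as the target (a higher number here means that more compound is needed for the effect, a lower number that less compound is needed), where compound 2 gives 56 mg/kg. Within the data shown here, compound 1 `CCOC(=O)CC(=O)N1CCSC1COc1ccccc1OC` gives 21 mg/kg, and the only measured step is a 2.7-fold higher number from compound 1 to compound 2 (0.43 log units; beyond the scatter). Compound 3 `COc1ccccc1OCC1SCCN1C(=O)CC(=O)NCc1ccccn1` differs from compound 2 by pyridin-2-yl in place of (diethylamino)methyl on a saturated chain carbon bound to an amide-type nitrogen. Among the measured compounds shown here, no measured step covers a change of this kind, and the one step known is modest, so the change is expected to leave the number close to compound 2, with a 1.4-fold lower number from compound 2 to compound 3 (0.15 log units; within the scatter). For compound 3 the estimate is 40 mg/kg, within a range from 18 mg/kg to 90 mg/kg.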

Compound 3, dose for half-maximal effect: 26 mg/kg
Compound 3: the middle estimate sits 1.5-fold (0.19 log units) above what was measured, and the stated range covers the measured number.
By their numbers in this assay, from the lowest: compounds 1 and 3 (each within the scatter of the next); then compound 2.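

Pyridin-2-yl in place of (diethylamino)methyl on this saturated chain carbon bound to an amide-type nitrogen gives a 2.2-fold lower number from compound 2 to compound 3 (0.33 log units; beyond the scatter) in this assay, so the group at this end of the side chain matters to the dose needed. Measured against ethoxy on the carbonyl carbon, ((pyridin-2-yl)methyl)amino gives a 1.2-fold higher number from compound 1 to compound 3 (0.09 log units; within the scatter), so these two stand level, which the (2-(diethylamino)ethyl)amino group did not. Nothing measured here gives a reason for the shift.

The compounds shown leave open whether phenyl in place of pyridin-2-yl would move the number. On these data alone, a longer chain carrying pyridin-2-yl is equally open.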